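Phenoxy in place of methyl on the aryl ring of compound 1

The source may report more compounds than this note shows. Statements on the series, on what has been measured and on what is new or still open speak of the compounds shown alone.

Measured compounds and their values in the paw edema read-out:
compound 1 `Cc1ccc(C2=NN(c3ccc(S(C)(=O)=O)cc3)C(=O)CC2)cc1`, 60.5%
compound 2 `CS(=O)(=O)c1ccc(N2N=C(c3ccc(-c4ccccc4)cc3)CCC2=O)cc1`, 21%
compound 3 `CS(=O)(=O)c1ccc(N2N=C(c3ccc(Cl)cc3)CCC2=O)cc1`, 36.8%

The three compounds share a core and differ only in the group on one aromatic carbon. In a functional assay on the whole organism (strain Wistar) for inhibition, with Rattus norvegicus as the target, read by paw edema, with stated times of 30 min and 5 h, at a dose of 0.05 mmol/kg by the oral route (on this read-out lower numbers stand for less inhibition and higher numbers for more inhibition at the one dose given (going by the name of the read-out)), compound 1 gives 60.5%, the highest of the three numbers, and both its steps to the others lie beyond the scatter: a number 39.5 percentage points lower from compound 1 to compound 2 (beyond the scatter) and a number 23.7 percentage points lower from compound 1 to compound 3 (beyond the scatter). Between the two lower compounds, a number 15.8 percentage points higher from compound 2 to compound 3 (beyond the scatter).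

Compound 4 `CS(=O)(=O)c1ccc(N2N=C(c3ccc(Oc4ccccc4)cc3)CCC2=O)cc1` carries phenoxy in place of methyl on an aromatic carbon. Going by the values given here, the change that bears most on it is the one to compound 2, where phenyl, another six-membered aromatic ring of carbon only, entered in place of methyl and the number fell by a large step. The step to compound 3, where chloro entered, was smaller but in the same direction. Both measured replacements of methyl lowered the inhibition, so a fall beyond the scatter in this assay is expected for compound 4 as well, of a size between the two measured steps or close to the larger one.

The estimate for compound 4 is therefore 28%, with a range from 10% to 48%, which is expected to mean a number 32.5 percentage points lower from compound 1 to compound 4 (beyond the scatter).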

Compound 4, a percentage reported as inhibition, in the whole organism at one dose (the size of the read-out at that dose, not a potency): 65.7%
Estimate against measurement, compound 4: 37.7 percentage points below; the measured number lies above the stated range.
By their numbers in this assay, from the lowest: compound 2; then compound 3; then compounds 1 and 4 (each within the scatter of the next).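

In this assay, the place para to a large group proves able to take a much bigger group than methyl without a loss: with phenoxy, a group of 7 heavy atoms carrying one six-membered aromatic ring, the result is a number 5.2 percentage points higher from compound 1 to compound 4 (within the scatter) and, unlike phenyl and chloro, this replacement of methyl does not leave the number lower. Going by these compounds alone, the fall seen with phenyl therefore does not extend to every group carrying such a ring, for phenoxy differs from phenyl by its one oxygen and the comparison gives a number 44.7 percentage points higher from compound 2 to compound 4 (beyond the scatter), while the change from chloro gives a number 28.9 percentage points higher from compound 3 to compound 4 (beyond the scatter) as well. No measurement shown accounts for the difference that the oxygen-linked ring makes here.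

Going by these compounds, what a methoxy group or an anilino group, with nitrogen in place of the phenoxy oxygen, would give at this position remains open, as does the effect of a chloro or methyl group on the phenoxy ring itself. On these data alone, with one dose behind each number, it also remains open how compound 1 and compound 4 would compare at other doses.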